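Chloro removal on the pendant aryl in two cores

The source may hold more compounds than are shown below. What is called first, only, known or untested is meant among the compounds shown, and "the series" means these compounds.

Measured compounds:
compound 1 `COc1ccc2nc(NC(c3cn(-c4ccccc4)nc3-c3ccc(Cl)cc3)c3c(O)ccc4ccccc34)sc2c1`: 23700 nM
compound 2 `COc1ccc2nc(NC(c3cn(-c4ccccc4)nc3-c3ccccc3)c3c(O)ccc4ccccc34)sc2c1`: 40800 nM
compound 3 `Oc1ccc2ccccc2c1C(Nc1nc2ccc(Cl)cc2s1)c1cn(-c2ccccc2)nc1-c1cccc(Cl)c1`: 17500 nM

All three were run in a functional assay on MCF7 cells (Homo sapiens) for antiproliferative activity, read by MTT assay, with a stated time of 48 h; a lower number here means a stronger inhibitor, a higher number a weaker inhibitor. Compound 1 gives 23700 nM there, and compound 2 gives 40800 nM; the two differ only by hydrogen in place of chloro on an aromatic carbon, and that change made a 1.7-fold higher number from compound 1 to compound 2 (0.24 log units; within the scatter). Compound 3 gives 17500 nM; its number is the lowest of the three, but the gap to compound 1 lies within the scatter, while the gap to compound 2 lies beyond it. How the core of compound 3 differs from the core of compound 1 is not broken down here.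

Compound 4 `Oc1ccc2ccccc2c1C(Nc1nc2ccc(Cl)cc2s1)c1cn(-c2ccccc2)nc1-c1ccccc1` is not yet measured. It differs from compound 3 by hydrogen in place of chloro on an aromatic carbon. This is the same kind of change as from compound 1 to compound 2, not the same: there the chloro sat para to a large group, here it sits meta to a large group, and the two cores differ as well. Among the measured compounds shown here, only one earlier instance of this kind exists, and it made a 1.7-fold higher number from compound 1 to compound 2 (0.24 log units; within the scatter). The step from compound 3 to compound 4 is expected to be about that size, that is a 1.5-fold higher number from compound 3 to compound 4 (0.19 log units; within the scatter), a shift that may itself stay within the scatter. On that basis compound 4 is expected to give 27000 nM, with a plausible range from 12000 nM to 60000 nM.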

Compound 4, half-maximal inhibitory concentration: 36300 nM
Compound 4: the middle estimate sits 1.3-fold (0.13 log units) below what was measured; the range from low to high includes it.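

In this assay, removing the chloro from the pendant aryl, read here as 3-chlorophenyl to phenyl, gives a 2.1-fold higher number from compound 3 to compound 4 (0.32 log units; beyond the scatter), and the step points the same way as on the other core, with a size that can be called the same: the same change on two cores in this assay, a 1.7-fold higher number (0.24 log units; within the scatter) from compound 1 to compound 2 and a 2.1-fold higher number (0.32 log units; beyond the scatter) from compound 3 to compound 4, 1.2-fold (0.08 log units) apart, within the scatter of two such steps. The two cores also stay close once both carry a plain phenyl, since the exchange of methoxy for chloro on the shared core gives a 1.1-fold lower number from compound 2 to compound 4 (0.05 log units; within the scatter). This supports carrying the change between these two cores as one modest step in the same direction, but it rests on two pairs only, one of which stays within the scatter, and the chloro changes its place on the aryl along with the change of core, so neither the place nor the core can be read separately, and nothing is shown for any other core.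

As far as these compounds go, it remains open whether the chloro would give a step of this size at the other place on each core, with the two placements tested on one and the same core. From the compounds shown here alone, it is also open whether another group on the pendant aryl, such as a nitrile or an amine, would move the number in the same direction as the chloro.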